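Swapping cyclohexyl for thiophen-2-yl on a carbonyl carbon

The source may hold more compounds than are shown below. What is called first, only, known or untested is meant among the compounds shown, and "the series" means these compounds.

Measured so far in an ADME assay on cells (Hepatocyte, Mus musculus) for metabolic stability; on this read-out higher numbers stand for a longer-lived compound and lower numbers for a shorter-lived compound:
Compound 1 `O=C(NC1CCC(CN2CCN(c3cc(=O)c4cc(C(F)(F)F)cc([N+](=O)[O-])c4s3)CC2)CC1)c1ccccc1` gives > 1.55 h (a limit, not a number)
Compound 2 `O=C(OC1CCC(CN2CCN(c3cc(=O)c4cc(C(F)(F)F)cc([N+](=O)[O-])c4s3)CC2)CC1)c1ccc(C(F)(F)F)cc1` gives 0.278 h
Compound 3 `O=C(OC1CCC(CN2CCN(c3cc(=O)c4cc(C(F)(F)F)cc([N+](=O)[O-])c4s3)CC2)CC1)C1CCCCC1` gives 0.0783 h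

Among the actual numbers, compound 3 at 0.0783 h is the lowest, with compound 2 as its nearest neighbour. Compound 4 `O=C(OC1CCC(CN2CCN(c3cc(=O)c4cc(C(F)(F)F)cc([N+](=O)[O-])c4s3)CC2)CC1)c1cccs1` differs from compound 3 in one place, on a carbonyl carbon, where thiophen-2-yl stands in place of cyclohexyl thiophen-2-yl in place of cyclohexyl on a carbonyl carbon and the rest stays the same.

Two measured steps end at compound 3. The one that bears directly is a 3.6-fold lower number from compound 2 to compound 3 (0.55 log units; beyond the scatter) and it changes the group at this same place. Read backwards, it shows a higher number with an aromatic ring, 4-(trifluoromethyl)phenyl, than with cyclohexyl. The other, an at least 19-fold lower number from compound 1 to compound 3 (1.29 log units; beyond the scatter), changes a part that compound 4 leaves untouched, so it offers little guidance here.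

Thiophen-2-yl is also an aromatic ring, though a different one, and this single pair is the only guide. A modest rise in this assay is therefore expected, similar to or slightly smaller than that pair's gap. The estimate amounts to an expected 2.4-fold higher number from compound 3 to compound 4 (0.38 log units; beyond the scatter) in this read-out. Compound 4 is estimated at 0.19 h, with an expected range from 0.08 h to 0.45 h.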

Compound 4, half-life: 0.0867 h
For compound 4 the middle estimate is 2.2-fold (0.34 log units) above the measured one; low and high end bracket the measured number.
By their numbers in this assay, from the lowest: compounds 3 and 4 (each within the scatter of the next); then compound 2. At a limit, above all of these: compound 1.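

In this assay, an aromatic ring on this carbonyl carbon does not by itself set the number apart from a saturated ring: thiophen-2-yl in place of cyclohexyl gives a 1.1-fold higher number from compound 3 to compound 4 (0.04 log units; within the scatter). The gain linked to 4-(trifluoromethyl)phenyl therefore does not extend to every aromatic ring, since thiophen-2-yl in its place gives a 3.2-fold lower number from compound 2 to compound 4 (0.51 log units; beyond the scatter). The change at the saturated ring carbon, from benzamido to ((thiophen-2-yl)carbonyl)oxy, gives a much larger step, an at least 17-fold lower number from compound 1 to compound 4 (1.25 log units; beyond the scatter), though that step starts from a limit and not from a number: the limit of > 1.55 h in this assay, at which 1 of the 4 values shown sits.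

On these data alone, it remains open whether the higher number with 4-(trifluoromethyl)phenyl belongs to the phenyl ring or to its trifluoromethyl group, a question that a plain phenyl on this carbonyl carbon would address. As far as these compounds go, it is also open how thiophen-2-yl would behave in an amide like that of compound 1, which would show whether the group on the carbonyl carbon still counts once the linking oxygen gives way to the amide nitrogen.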